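The compounds below may be only part of what the source reports. "The series", "measured", "known", "first", "only" and "open" are said of these compounds alone.

Working notes on the series. Compound 1 `O=C(NC1CCCCC1)c1cc(/N=C/c2cc(O)ccc2O)ccc1O` and compound 2 `CCCCNC(=O)c1cc(NCc2cc(O)ccc2O)ccc1O` share the same core and differ at the amide substituent and at the linker to the second ring. In an assay on isolated protein for inhibition of Polyunsaturated fatty acid 5-lipoxygenase (Homo sapiens) (on this read-out lower numbers stand for stronger inhibition and higher numbers for weaker inhibition), compound 1 gives 11300 nM. In this assay, for the measured compounds named here, compound 2 gives 10500 nM, the lowest of the two numbers so far, but the gap to compound 1 falls within the usual scatter, so no order between them can be claimed. Compound 3 `CCCCCCNC(=O)c1cc(NCc2cc(O)ccc2O)ccc1O` is yet to be measured; it differs from compound 2 by ethyl in place of hydrogen on a saturated chain carbon, four bonds along the chain from an amide-type nitrogen. Going by the values given here, no step between measured compounds covers this kind of change, so the only guide is that both numbers so far sit close together; a step of a 1.3-fold lower number from compound 2 to compound 3 (0.12 log units; within the scatter) is expected, which may well lie within the scatter. Compound 3 is estimated at 8000 nM, with a range from 3000 nM to 25000 nM.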

Compound 3, half-maximal inhibitory concentration: 11900 nM
Compound 3: the middle estimate sits 1.5-fold (0.17 log units) below what was measured; measured number inside the range.
By their numbers in this assay, from the lowest: compounds 2, 1 and 3 (each within the scatter of the next).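

For the compounds shown here, this is the first step that changes one place only: ethyl in place of hydrogen on a saturated chain carbon, four bonds along the chain from an amide-type nitrogen, gives a 1.1-fold higher number from compound 2 to compound 3 (0.05 log units; within the scatter) in this assay as the read-out. At this position, then, the added ethyl leaves no difference that can be told from the scatter, and compound 2 and compound 3 cannot be put in order. Nothing measured beyond these numbers bears on this result.

Going by these compounds, whether a longer chain, an amine or a carboxylic acid at this position would give a step beyond the scatter remains open. On these data alone, compound 1 differs from the others in more than one place, so the separate contributions of its amide substituent and its linker also remain open.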